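Compound 1 to compound 4: cyclopropyl to 4-chlorophenyl

The source may report more compounds than this note shows. Statements on the series, on what has been measured and on what is new or still open speak of the compounds shown alone.

Measured values in a functional assay on A2780 cells (Homo sapiens) for antiproliferative activity, read by fluorescence, with a stated time of 72 h (on this read-out lower numbers stand for stronger inhibition and higher numbers for weaker inhibition), are as follows
- compound 1 `CN1CCC(C(=O)N2Cc3c(NC(=O)C4CC4)n[nH]c3C2(C)C)CC1` gives 1420 nM
- compound 2 `CC(C)(C)C(=O)N1Cc2c(NC(=O)C3CCNCC3)n[nH]c2C1(C)C` gives 650 nM
- compound 3 `CN(C)CC(=O)Nc1n[nH]c2c1CN(C(=O)C(C)(C)C)C2(C)C` gives 580 nM

Compound 1 has the highest number of the three, and compound 2 and compound 3 both lie lower, beyond the scatter. Compound 4 `CN1CCC(C(=O)N2Cc3c(NC(=O)c4ccc(Cl)cc4)n[nH]c3C2(C)C)CC1` differs from compound 1 by one change, 4-chlorophenyl in place of cyclopropyl on a carbonyl carbon with 4-chlorophenyl in place of cyclopropyl on a carbonyl carbon. Among the measured compounds shown here, the only measured step, a 1.1-fold lower number from compound 2 to compound 3 (0.05 log units; within the scatter), also falls on a carbonyl carbon but exchanges different groups, so it offers weak guidance. No measurement covers this exchange. With compound 1 at 1420 nM at the top of the measured range, a modest move to a lower number in this assay is expected. The estimated change is a 2.0-fold lower number from compound 1 to compound 4 (0.31 log units; beyond the scatter), with wide uncertainty. Compound 4 is expected at 700 nM, with an estimated range of 180 nM to 2500 nM.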

Compound 4, half-maximal inhibitory concentration: 120 nM
Compound 4: middle estimate off by 5.8-fold (0.77 log units), on the high side; measured number outside the range, below it.
By their numbers in this assay, from the lowest: compound 4; then compounds 3 and 2 (each within the scatter of the next); then compound 1.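

On the carbonyl carbon whose other neighbour is the amide-type nitrogen, 4-chlorophenyl in place of cyclopropyl gives a 12-fold lower number from compound 1 to compound 4 (1.07 log units; beyond the scatter) in this assay. This position is therefore sensitive to the group it carries, which the earlier step, a 1.1-fold lower number from compound 2 to compound 3 (0.05 log units; within the scatter), exchanging other groups on a carbonyl carbon, did not reveal. No measured evidence accounts for the size of the new step.

On these data alone, whether the step comes from the aromatic ring or from its chlorine stays open; unsubstituted phenyl would separate the two. As far as these compounds go, whether a pyridine ring would serve here also remains unknown.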